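Removing One Chloro Group from a Purine-Like Core

The source may report more compounds than this note shows. Statements on the series, on what has been measured and on what is new or still open speak of the compounds shown alone.

Compound 1 `ClCc1ccc(Cn2cnc3c(Cl)ncnc32)cc1`: > 100000 nM
Compound 2 `ClCc1ccccc1Cn1cnc2c(Cl)nc(Cl)nc21`: "not determined" (no result reported)

Of the compounds shown here, two have been tested in a functional assay on COLO 205 cells (Homo sapiens) for cytotoxicity, read by sulforhodamine B assay, with a stated time of 48 h; on this read-out lower numbers stand for stronger inhibition of growth and higher numbers for weaker inhibition of growth. For compound 1 the result is only a limit, > 100000 nM. For compound 2 the outcome in this assay is "not determined" (no result reported), so no number is available for it, and nothing can be said about a step from compound 2 to any other compound on the basis of measurements. What is shown is summed up in the limit of > 100000 nM in this assay, at which 1 of the 2 values shown sits.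

Compound 3 `ClCc1ccccc1Cn1cnc2c(Cl)ncnc21` has not yet been measured. It differs from compound 2 by one change: hydrogen in place of chloro on an aromatic carbon. Going by the values given here, with no number for compound 2, and with the only measured relative, compound 1, sitting at a limit, there is no measured step to lean on, and no size or direction can be given for the change from compound 2 to compound 3 beyond the scatter. Compound 3 is expected to give about 100000 nM in this assay, within a range of 30000 nM to 300000 nM, and the result may again be reported only as a limit.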

Compound 3, concentration for total growth inhibition: > 100000 nM
Compound 3: a limit, no number; the forecaster's own chance of this, stated with the estimate: 65%; the middle value sits exactly at the limit.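

Compound 3 gives only a limit, > 100000 nM. Going by these compounds alone, compound 2 has no number to set against it, so no step from compound 2 to compound 3 can be read. Still open is whether hydrogen in place of chloro between two ring nitrogen atoms changes growth inhibition, and how strong any of these compounds really is: the limit of > 100000 nM in this assay, at which 2 of the 3 values shown sit.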